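A Bromine-Bearing Phenyl Group in Place of Dimethylphenyl

The source may hold more compounds than are shown below. What is called first, only, known or untested is meant among the compounds shown, and "the series" means these compounds.

compound 1 `NC1=NC2(CCOCC2)N(OCCCOc2ccccc2)C(N)=N1`: "not determined" (no result reported)
compound 2 `NC1=NC2(CCOCC2)N(OCCCOc2ccc(Cl)cc2)C(N)=N1`: "not determined" (no result reported)
compound 3 `Cc1cc(C)cc(OCCCON2C(N)=NC(N)=NC23CCOCC3)c1`: 680 nM

In a functional assay on HepG2 cells (Homo sapiens) for antiproliferative activity, read by MTT assay, with a stated time of 72 h (a higher number here means a weaker inhibitor, a lower number a stronger inhibitor), compound 3 gives 680 nM. Within the data shown here, this is the only number available, as neither compound 1 nor compound 2 has a reported result, so compound 3 cannot be ranked against either of them.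

The next compound to be measured is compound 4 `NC1=NC2(CCOCC2)N(OCCCOc2ccccc2Br)C(N)=N1`. It keeps the shared core of compound 3 and the chain leading to the terminal oxygen, and it carries 2-bromophenyl in place of 3,5-dimethylphenyl on an oxygen on a saturated carbon.

Among the measured compounds shown here, the data contain no measured step between compounds that differ in one place, so they do not show how such an exchange moves the read-out. In this assay no step beyond the scatter is therefore expected, with only a slight lean towards weaker inhibition and real uncertainty about the direction. The expected change is a 1.5-fold higher number from compound 3 to compound 4 (0.17 log units; within the scatter). The only anchor for this expectation is compound 3 at 680 nM. For compound 4 the estimated value is 1000 nM, with an expected range from 250 nM to 4000 nM.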

Compound 4, half-maximal inhibitory concentration: 860 nM
For compound 4 the middle estimate is 1.2-fold (0.07 log units) above the measured one; low and high end bracket the measured number.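

In this assay, among these compounds, the exchange of 3,5-dimethylphenyl for 2-bromophenyl on an oxygen on a saturated carbon gives the first readable step at this position: a 1.3-fold higher number from compound 3 to compound 4 (0.10 log units; within the scatter). The change therefore leaves the read-out within the usual scatter, even though the entering group has one heavy atom fewer and swaps an all-carbon group for one that carries bromine, while both keep one six-membered aromatic ring of carbon only, with no hydrogen-bond donors or acceptors and no net charge. No supporting data bear on why these two groups read alike.

Steps to compound 1 and compound 2 cannot be read, so this single pair is all that speaks for the position, and it claims no pattern beyond compound 3 and compound 4. As far as these compounds go, it remains open whether an aromatic ring carrying an amine or a carboxylic acid would stay within the scatter in the same way, and whether a longer chain leading to the terminal oxygen would do so.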